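Phenol in place of chloro on the aryl of compound 3

The source may report more compounds than this note shows. Statements on the series, on what has been measured and on what is new or still open speak of the compounds shown alone.

Of the compounds shown here, three of the shared core have been measured in a functional assay on LNCaP cells (Homo sapiens) for antiproliferative activity, read by MTT assay, with a stated time of 24 h; on this read-out higher numbers stand for weaker inhibition and lower numbers for stronger inhibition. Compound 1 `COc1ccc(-c2noc(-c3ccc(F)cc3)n2)cc1O` returns only a limit, > 1000000 nM. Compound 2 `COc1cc(-c2noc(-c3ccncc3)n2)ccc1OCc1ccccc1` also returns only a limit, > 1000000 nM. For the measured compounds named here, compound 3 `COc1ccc(-c2noc(-c3ccc(Cl)cc3)n2)cc1OC1CCCC1` is the one member with a number, 20800 nM, and so stands alone among the values shown. The other two values are the limit of > 1000000 nM in this assay, at which 2 of the 3 values shown sit.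

Compound 4 `COc1ccc(-c2noc(-c3ccc(O)cc3)n2)cc1OC1CCCC1` has not been measured. It differs from compound 3 in one place: hydroxy in place of chloro on an aromatic carbon. Going by the values given here, no step between two measured compounds is known, so no measured change of this kind can be drawn on; the expectation rests on compound 3 alone, whose 20800 nM shows that a number is reached with chloro at that aromatic carbon. In this assay the step is expected to be small, within the scatter or a modest move toward weaker inhibition, and the estimated step is a 1.4-fold higher number from compound 3 to compound 4 (0.16 log units; within the scatter). Compound 4 is estimated at 30000 nM, within 8000 nM to 150000 nM, with a real chance that only a limit is returned.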

Compound 4, half-maximal inhibitory concentration: 860 nM
The estimate for compound 4 lay 35-fold (1.54 log units) above the measured number; measured number below the stated range.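

The aromatic carbon para to a large group proves to be a sensitive position in this assay: hydroxy in place of chloro gives a 24-fold lower number from compound 3 to compound 4 (1.38 log units; beyond the scatter). For the compounds shown here, the earlier compounds offered no measured pair, so this is the first sign that the group at this carbon can move the read-out well beyond the scatter. The exchange is of one heavy atom for one heavy atom, with a hydrogen-bond donor and a hydrogen-bond acceptor entering by count, and the data do not tell which feature of hydroxy accounts for the step.

Going by these compounds, whether an amine, a methoxy or a carboxylic acid at this carbon would read like hydroxy stays open. Whether the step carries over when the rest of compound 4 is changed also stays open, and numbers remain scarce in the set: the limit of > 1000000 nM in this assay, at which 2 of the 4 values shown sit.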